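Swapping a Methyl for Fluoro on the Amide Aryl Ring

A few compounds are considered here, and "the series" means these few. Any claim that something is new, unique, unknown or untested is made for them only; others in the source may bear on it.

Three compounds have been measured in a functional assay on MCF7 cells (Homo sapiens) for inhibition, read by MTT assay, with a stated time of 72 h; on this read-out higher numbers stand for weaker inhibition and lower numbers for stronger inhibition:
Compound 1 `Cc1ccc(C)c(NC(=O)c2ccc(/N=N\c3c[nH]c4ccccc34)cc2)c1` gives 29900 nM.
Compound 2 `Cc1ccc(NC(=O)c2ccc(/N=N\c3c[nH]c4ccccc34)cc2)c(C)c1` gives 87000 nM.
Compound 3 `Cc1ccccc1NC(=O)c1ccc(/N=N\c2c[nH]c3ccccc23)cc1` gives 73400 nM.

All three share the same core and differ only in the methyl groups on the ring attached to the amide nitrogen. Compound 3 has the second highest number of the three. Its nearest neighbour is compound 2: a 1.2-fold lower number from compound 2 to compound 3 (0.07 log units; within the scatter). Its furthest is compound 1: a 2.5-fold higher number from compound 1 to compound 3 (0.39 log units; beyond the scatter).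

Compound 4 `O=C(Nc1ccccc1F)c1ccc(/N=N\c2c[nH]c3ccccc23)cc1` is the next step from compound 3. The change is fluoro in place of methyl on an aromatic carbon. The measured steps all concern adding or moving methyl groups on this ring; none shows what fluoro does in place of methyl. The step from compound 1 to compound 3 shows that losing a methyl on this ring can move the number modestly, while the step from compound 2 to compound 3 stays within the scatter. A fluoro in place of the methyl is therefore expected to give a step of a 1.1-fold lower number from compound 3 to compound 4 (0.05 log units; within the scatter), with wide uncertainty. The estimate for compound 4 in this assay is 65000 nM, in a range from 20000 nM to 200000 nM.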

Compound 4, half-maximal inhibitory concentration: 83800 nM
Compound 4: the middle estimate sits 1.3-fold (0.11 log units) below what was measured; measured number inside the range.
By their numbers in this assay, from the lowest: compound 1; then compounds 3, 4 and 2 (each within the scatter of the next).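

At this position on the ring, swapping methyl for fluoro makes no readable difference in this assay (a 1.1-fold higher number from compound 3 to compound 4 (0.06 log units; within the scatter)), the first sign that this place tolerates a group other than methyl without a shift beyond the scatter. The 2-fluorophenyl compound also cannot be told apart from the 2,4-dimethylphenyl compound (a 1.0-fold lower number from compound 2 to compound 4 (0.02 log units; within the scatter)), whereas the 2,5-dimethylphenyl compound stays clearly separate (a 2.8-fold higher number from compound 1 to compound 4 (0.45 log units; beyond the scatter)), so compound 1 keeps the lowest number of the four. Nothing available explains why these two groups read alike here.

On these data alone, whether the same swap would leave the number of compound 1 unchanged remains open. So does the effect of a methoxy group, an amine or a carboxylic acid at this place on the ring.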